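Replacing the carbamate of compound 3 with a benzamide

A few compounds are considered here, and "the series" means these few. Any claim that something is new, unique, unknown or untested is made for them only; others in the source may bear on it.

Three analogues sharing one core have been measured in an assay on LtK cells with ATP-sensitive inward rectifier potassium channel 11 (Homo sapiens) as the target; a higher number here means that more compound is needed for the effect, a lower number that less compound is needed. Compound 1 `CC(=O)Nc1c(C(O)(C(F)(F)F)C(F)(F)F)ccc2ccccc12` carries a methyl on the carbonyl carbon and gives 18 nM. Compound 2 `O=C(NCCCCCCCl)Nc1c(C(O)(C(F)(F)F)C(F)(F)F)ccc2ccccc12` gives 4840 nM, and compound 3 `CC(C)OC(=O)Nc1c(C(O)(C(F)(F)F)C(F)(F)F)ccc2ccccc12` gives 1160 nM. Among these three numbers compound 3 stands second highest: it lies a 4.2-fold lower number from compound 2 to compound 3 (0.62 log units; beyond the scatter), while a 64-fold higher number from compound 1 to compound 3 (1.81 log units; beyond the scatter).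

Compound 4 `O=C(Nc1c(C(O)(C(F)(F)F)C(F)(F)F)ccc2ccccc12)c1ccc(I)cc1` is the next step. Compared with compound 3 the change is 4-iodophenyl in place of isopropoxy on a carbonyl carbon, so the carbonyl carbon now carries an aromatic ring instead of an oxygen-linked chain.

Within the data shown here, two measured steps bear on this. Enlarging the group on the carbonyl carbon has so far pushed the number up: a 270-fold higher number from compound 1 to compound 2 (2.43 log units; beyond the scatter) and a 64-fold higher number from compound 1 to compound 3 (1.81 log units; beyond the scatter). Between the two larger groups the difference was smaller, shown by a 4.2-fold lower number from compound 2 to compound 3 (0.62 log units; beyond the scatter). Among the measured compounds shown here, no measured compound carries an aromatic ring at this position, so how far this new group moves the number is uncertain, but a rise is the expected direction.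

Compound 4 is therefore expected to give 2500 nM in this assay, within a range of 400 nM to 15000 nM, which corresponds to an expected step of a 2.2-fold higher number from compound 3 to compound 4 (0.33 log units; beyond the scatter).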

Compound 4, half-maximal effective concentration: 154 nM
Compound 4: the middle estimate sits 16-fold (1.21 log units) above what was measured, outside the stated range (below it).
By their numbers in this assay, from the lowest: compound 1; then compound 4; then compound 3; then compound 2.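

In this assay, the count of heavy atoms on the carbonyl carbon does not by itself set the number: 4-iodophenyl has more heavy atoms than isopropoxy, yet the change gives a 7.5-fold lower number from compound 3 to compound 4 (0.88 log units; beyond the scatter). So the earlier rise seen with larger groups does not extend to every larger group, and compound 4 is the compound that goes against it. The same ring also compares well with the (6-chlorohexyl)amino group, with a 31-fold lower number from compound 2 to compound 4 (1.50 log units; beyond the scatter), but it does not match the small methyl group, since an 8.6-fold higher number from compound 1 to compound 4 (0.93 log units; beyond the scatter) leaves compound 1 with the lowest number of the four.

The compounds shown do not separate the part played by the six-membered aromatic ring from that of the iodine, so an unsubstituted phenyl, a 4-chlorophenyl or a saturated cyclohexyl ring on the same carbonyl carbon would be the informative comparisons. Why the 4-iodophenyl group gives a lower number than the isopropoxy group also stays unexplained, as nothing available here speaks to it.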